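This account rests on a few compounds, and the source may have more. Where it says the series, first, only, none or still open, it means among the compounds named here.

Measured so far:
Compound 1, `COc1ccccc1C1C(C#N)=C(N)N(c2ccc(S(N)(=O)=O)cc2)C2=C1CCCC2`: 50%
Compound 2, `N#CC1=C(N)N(c2ccc(S(N)(=O)=O)cc2)C2=C(CCCC2)C1c1cccc([N+](=O)[O-])c1`: 2%

In a functional assay on Ehrlich cells (Mus musculus) for cytotoxicity, read by trypan blue exclusion, with a stated time of 2 h, tested at 50 ug/mL (a higher number here means a stronger effect of the compound at the concentration tested, a lower number a weaker effect), compound 2 stands lowest of the two numbers; its nearest neighbour is compound 1, which is higher by a number 48 percentage points lower from compound 1 to compound 2 (beyond the scatter) reversed, a gap beyond the usual scatter. Compound 3, `Cc1ccc(C2C(C#N)=C(N)N(c3ccc(S(N)(=O)=O)cc3)C3=C2CCCC3)o1`, has not been measured in this assay. The change from compound 2 to compound 3 is 5-methylfuran-2-yl in place of 3-nitrophenyl on a saturated ring carbon. Among the measured compounds shown here, only one measured step bears on this position: from compound 1 to compound 2 the read-out fell by a number 48 percentage points lower from compound 1 to compound 2 (beyond the scatter) when the group on that saturated ring carbon was exchanged, showing that this position can move the read-out by a large amount. For the measured compounds named here, no measured compound carries the 5-methylfuran-2-yl group, so the direction is uncertain. For compound 3 the estimate is 25%, with a range from 3% to 55%. The expected step is a number 23 percentage points higher from compound 2 to compound 3 (beyond the scatter), upward but with wide uncertainty.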

Compound 3, a percentage reported as activity, at one concentration (the size of the read-out at that concentration, not a potency): 10%
Beside the measured number, compound 3's estimate is 15 percentage points above it; low and high end bracket the measured number.
By their numbers in this assay, from the lowest: compounds 2 and 3 (each within the scatter of the next); then compound 1.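

In this assay, the exchange of 3-nitrophenyl for 5-methylfuran-2-yl on the saturated ring carbon gives a number 8 percentage points higher from compound 2 to compound 3 (within the scatter), so these two quite different groups, a six-membered carbon ring bearing a nitro group and a five-membered ring with a hetero atom, cannot be told apart here. Against the 2-methoxyphenyl group the exchange gives a number 40 percentage points lower from compound 1 to compound 3 (beyond the scatter), a drop of the same large kind as the first step, which leaves compound 1 alone at the high end and shows that the earlier drop was not peculiar to 3-nitrophenyl. Nothing available explains why these groups behave this way.

Going by these compounds, whether the read-out of compound 1 rests on the methoxy group itself or on the ring that carries it stays open. A plain phenyl or a 3-methoxyphenyl group at this carbon would help separate the two.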